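Pyrazolyl for oxadiazolyl on the benzyl arm of compound 1

A few compounds are considered here, and "the series" means these few. Any claim that something is new, unique, unknown or untested is made for them only; others in the source may bear on it.

Compound 1, `Cc1cc(C)c(NC(=O)N(Cc2ccc(-c3nnc(C)o3)cc2)C2CCCCCC2)c(C)c1`, is known in a functional assay on a cell-free system (plasma) with sterol O-acyltransferase, Soat (Rattus norvegicus) as the target (a lower number here means that less compound is needed, a higher number that more compound is needed for the effect), only as a limit: compound 1 gives > 0.32 mg/kg, which is a limit of this assay and not a number (the limit of > 0.32 mg/kg in this assay, at which 1 of the 3 values shown sits). Two other compounds of the series carry numbers. Compound 2, `CSc1cc(C)nc(SC)c1NC(=O)N(Cc1ccccc1)Cc1cccc(-c2cc[nH]n2)c1`, gives 0.046 mg/kg in this assay. Compound 3, `Cc1cc(C)c(NC(=O)N(Cc2cccc(-n3cccc3)c2)C2CCCCCC2)c(C)c1`, gives 0.17 mg/kg in this assay. No pair among these differs in a single place, so no measured step is available, and the values of compound 2 and compound 3 are the only points of reference for what the series can reach.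

Compound 4, `Cc1cc(C)c(NC(=O)N(Cc2ccc(-n3cccn3)cc2)C2CCCCCC2)c(C)c1`, is not yet measured. It differs from compound 1 by 1H-pyrazol-1-yl in place of 5-methyl-1,3,4-oxadiazol-2-yl on an aromatic carbon, para to a large group. Compound 3 shows that a five-membered ring attached through nitrogen to the benzyl arm can sit well inside the range of the series, but it sits at another position, so no direct read-across exists.

Compound 4 is expected to give 0.25 mg/kg in this assay, with a range from 0.08 mg/kg to 1 mg/kg; the expected step from compound 1 to compound 4 is an at least 1.2-fold lower number from compound 1 to compound 4 (0.10 log units; that floor lies within the scatter), toward a lower number, though a limit remains a real possibility.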

Compound 4, dose for half-maximal effect: > 1 mg/kg
Compound 4: no number, only a limit; the forecaster's own chance of this, stated with the estimate: 40%; middle value at least 4.0-fold (0.60 log units) away from the limit.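

In this assay compound 1 gives > 0.32 mg/kg, which is a limit and not a number. Compound 4 gives > 1 mg/kg, also a limit. Among these compounds, with only limits on both sides, no step between compound 1 and compound 4 can be read. The compounds shown leave open whether 1H-pyrazol-1-yl and 5-methyl-1,3,4-oxadiazol-2-yl differ at all in this place.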